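Demethylation of compound 2: a hydroxyl at the aryl ether

The source may report more compounds than this note shows. Statements on the series, on what has been measured and on what is new or still open speak of the compounds shown alone.

Compound 1 `Cc1cc(O)cc(-c2nn(CC#N)cc2-c2ccnc(-c3ccc(Oc4ccccc4)cc3)c2)c1`: 84%
Compound 2 `COc1cc(C)cc(-c2nn(CC#N)cc2-c2ccnc(-c3ccc(N(C)C)cc3)c2)c1`: 24%

In a functional assay on T47D cells (Homo sapiens) for cytotoxicity, read by sulforhodamine B assay, with a stated time of 48 h, tested at 100 nM (a lower number here means a stronger effect, a higher number a weaker effect of the compound at the concentration tested), compound 2 gives the lower of the two numbers shown, and compound 1 gives a markedly higher number, a gap beyond the usual scatter. Compound 3 `Cc1cc(O)cc(-c2nn(CC#N)cc2-c2ccnc(-c3ccc(N(C)C)cc3)c2)c1` differs from compound 2 in one place: hydrogen in place of methyl on an oxygen on an aromatic ring. Within the data shown here, no measured pair shows this change on its own, so its size is unknown; a small to moderate step toward weaker effect seems plausible. Compound 3 is expected to give 38%, within 15% to 68%. The step of a number 14 percentage points higher from compound 2 to compound 3 (beyond the scatter) is the estimate implied.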

Compound 3, a percentage reported as activity, at one concentration (the size of the read-out at that concentration, not a potency): 82%
The estimate for compound 3 lay 44 percentage points below the measured number, and the stated range ends below it.
By their numbers in this assay, from the lowest: compound 2; then compounds 3 and 1 (each within the scatter of the next).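

In this assay, the change from methoxy to hydroxy on the aromatic ring is a large step, a number 58 percentage points higher from compound 2 to compound 3 (beyond the scatter), so this one oxygen substituent alone separates compound 2 from compound 3. With the hydroxy group in place, dimethylamino in place of phenoxy gives a number 2 percentage points lower from compound 1 to compound 3 (within the scatter). No measurement here offers a reason for the large step.

Still open, going by these compounds, is how an ethoxy group or an amine would read at this position. Also open, on these data alone, is whether phenoxy alongside methoxy would match compound 2.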